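The source may hold more compounds than are shown below. What is called first, only, known or untested is meant among the compounds shown, and "the series" means these compounds.

Of the compounds shown here, three have been measured in an assay for inhibition of arginase-1 (Homo sapiens), read by scintillation counting, with a stated time of 5 min, tested at 200 uM; a lower number here means less inhibition, a higher number more inhibition at the concentration tested (going by the name of the read-out). Compound 1, `O=C(O)c1cccc(=O)n1O`, gives 2%, and compound 3, `Cc1cc(C(=O)O)c(O)c(=O)[nH]1`, gives 8%. Compound 2, `Cc1cc(=O)c(O)c(C(=O)O)[nH]1`, gives 24%, the highest of the three numbers; its gap to compound 3 and its larger gap to compound 1 both lie beyond the usual scatter. Compound 4, `Cc1cc(=O)c(O)c(C(=O)O)n1C`, differs from compound 2 only in one way: methyl in place of hydrogen on an aromatic nitrogen. Among the compounds with values here, no measured pair shows what this change does, so the expectation rests on compound 2 alone. Because compound 2 reaches only 24%, the estimated step from compound 2 to compound 4 is a number 9 percentage points lower from compound 2 to compound 4 (within the scatter), a small move downward or none beyond the scatter. Compound 4 is therefore expected to give about 15%, somewhere between 3% and 30%.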

Compound 4, a percentage reported as inhibition, at one concentration (the size of the read-out at that concentration, not a potency): 2%
The estimate for compound 4 lay 13 percentage points above the measured number, outside the stated range (below it).
By their numbers in this assay, from the lowest: compounds 1, 4 and 3 (each within the scatter of the next); then compound 2.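

In this assay, methyl in place of hydrogen on this aromatic nitrogen gives a number 22 percentage points lower from compound 2 to compound 4 (beyond the scatter), the first measured view of this change. At this position, ortho to a carboxy group and ortho to a methyl group, a single added carbon is enough to lose the inhibition seen with compound 2. Nothing shown gives a reason for this drop. From the compounds shown here alone, whether an ethyl group or a longer chain on this nitrogen would behave like methyl remains open. So does whether a chain ending in an amine would restore any inhibition.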